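The source may hold more compounds than are shown below. What is called first, only, known or untested is meant among the compounds shown, and "the series" means these compounds.

Compound 1 `Cc1cc(O)c(C2=NN(c3ccc(S(N)(=O)=O)cc3)C(c3ccccc3O)C2)cc1Cl` gives 3130 nM in a functional assay on ACHN cells (Homo sapiens) for antiproliferative activity, with a stated time of 48 h; on this read-out higher numbers stand for weaker inhibition of growth and lower numbers for stronger inhibition of growth.
Compound 2 `Cc1cc(O)c(C2=NN(c3ccc(S(N)(=O)=O)cc3)C(c3ccccc3Cl)C2)cc1Cl` gives 3340 nM in this assay.
Compound 3 `COc1ccc(C2CC(c3cc(Cl)c(C)cc3O)=NN2c2ccc(S(N)(=O)=O)cc2)cc1OC` gives 3150 nM in this assay.

All three compounds share one core and differ only in the group on the saturated ring carbon. Their numbers sit close together: the gap a 1.0-fold higher number from compound 1 to compound 3 (0.00 log units; within the scatter) and the gap a 1.1-fold lower number from compound 2 to compound 3 (0.03 log units; within the scatter) both fall inside the scatter, so compound 3 cannot be told apart from either neighbour. The new compound, compound 4 `COc1ccc(C2CC(c3cc(Cl)c(C)cc3O)=NN2c2ccc(S(N)(=O)=O)cc2)c(OC)c1OC`, is reached from compound 3 by a small change: methoxy in place of hydrogen on an aromatic carbon.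

For the measured compounds named here, no measured step adds a methoxy group in this way, so the closest evidence is indirect. The steps of a 1.0-fold higher number from compound 1 to compound 3 (0.00 log units; within the scatter) and a 1.1-fold lower number from compound 2 to compound 3 (0.03 log units; within the scatter) swapped the whole aryl group on that saturated carbon, and a 1.1-fold higher number from compound 1 to compound 2 (0.03 log units; within the scatter) swapped hydroxy for chloro; none moved the number beyond the scatter. Adding one more methoxy to an aryl that already carries two is therefore expected to give a step of a 1.0-fold higher number from compound 3 to compound 4 (0.01 log units; within the scatter), that is, no change beyond the scatter. Compound 4 is estimated at 3200 nM, with a range from 1500 nM to 6800 nM.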

Compound 4, concentration for 50% growth inhibition: 2780 nM
The estimate for compound 4 lay 1.2-fold (0.06 log units) above the measured number; the range from low to high includes it.
By their numbers in this assay, from the lowest: compounds 4, 1, 3 and 2 (each within the scatter of the next).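

In this assay, for the compounds shown here, this is the first direct reading of adding a methoxy group at this aromatic carbon, ortho to a large group and to a methoxy group, and the step stays within the scatter (a 1.1-fold lower number from compound 3 to compound 4 (0.05 log units; within the scatter)). The resulting 2,3,4-trimethoxyphenyl group also cannot be told apart from the 2-chlorophenyl group (a 1.2-fold lower number from compound 2 to compound 4 (0.08 log units; within the scatter)) or the 2-hydroxyphenyl group (a 1.1-fold lower number from compound 1 to compound 4 (0.05 log units; within the scatter)), so none of the four compounds separates from the others on this read-out. No measurement given here bears on this result.

The compounds shown leave open whether an amine or a carboxylic acid at this same aromatic carbon would move the number beyond the scatter. They also leave open whether a longer chain, such as butoxy, in place of the added methoxy would do so.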